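Amino gives way to a 3,5-dimethylpiperazin-1-yl group

A few compounds are considered here, and "the series" means these few. Any claim that something is new, unique, unknown or untested is made for them only; others in the source may bear on it.

Values in an ADME assay on CHO cells (Cricetulus griseus) for cytotoxicity, read by MTT assay; on this read-out higher numbers stand for weaker inhibition and lower numbers for stronger inhibition:
- Compound 1 `CS(=O)(=O)c1cccc(Nc2ccc3nccc(-c4ccncc4)c3n2)c1`: > 50000 nM, a limit of the assay
- Compound 2 `O=S(=O)(CCO)c1cccc(-c2ccc3nccc(-c4ccncc4)c3n2)c1`: 26000 nM
- Compound 3 `NS(=O)(=O)c1cccc(-c2ccc3nccc(-c4ccncc4)c3n2)c1`: 2000 nM

Within the data shown here, only two of these values are true numbers, and compound 3 has the lower of them. Compound 4 `C[C@@H]1CN(S(=O)(=O)c2cccc(-c3ccc4nccc(-c5ccncc5)c4n3)c2)C[C@H](C)N1` changes one group of compound 3, with 3,5-dimethylpiperazin-1-yl in place of amino on a sulfonyl sulfur. Among the measured compounds shown here, one measured step bears on this place: a 13-fold lower number from compound 2 to compound 3 (1.11 log units; beyond the scatter), a large step with amino in place of 2-hydroxyethyl. Amino now leaves, so a move back toward a higher number seems likely, although a single step is thin support. The expected step is a 3.0-fold higher number from compound 3 to compound 4 (0.48 log units; beyond the scatter), smaller than the measured one. For compound 4 the estimate is 6000 nM, within an expected range from 1500 nM to 25000 nM.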

Compound 4, half-maximal inhibitory concentration: 6000 nM
Beside the measured number, compound 4's estimate shows no gap at the digits printed, and the stated range covers the measured number.
By their numbers in this assay, from the lowest: compound 3; then compound 4; then compound 2. At a limit, above all of these: compound 1.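

With three groups now compared on the sulfonyl sulfur in this assay, 3,5-dimethylpiperazin-1-yl falls between the other two, above amino (a 3.0-fold higher number from compound 3 to compound 4 (0.48 log units; beyond the scatter)) and below 2-hydroxyethyl (a 4.3-fold lower number from compound 2 to compound 4 (0.64 log units; beyond the scatter)). Both steps lie beyond the scatter, so the number at this position does not simply switch between amino and everything else. A ring on this sulfur is compatible with an intermediate number, and amino keeps the lowest of the three.

As far as these compounds go, whether piperazin-1-yl without its two methyl groups, or morpholin-4-yl, would land nearby remains open. No measurement at hand explains the order of these three groups.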